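This account rests on a few compounds, and the source may have more. Where it says the series, first, only, none or still open, it means among the compounds named here.

Working notes on the series. Among the compounds with values here, in a functional assay on HCT-116 cells (Homo sapiens) for cytotoxicity, read by MTT assay, with a stated time of 3 days (a lower number here means a stronger inhibitor, a higher number a weaker inhibitor), compound 1 `CN(C)Cc1ccc(/C=N/Nc2ncnc3sc(C(C)(C)C)cc23)cc1` gives 0.128 ug/mL and compound 2 `CC(C)(C)c1cc2c(N/N=C/c3ccc(C(=O)O)cc3)ncnc2s1` gives 9.99 ug/mL, the higher of the two numbers so far. Next comes compound 3 `CC(C)(C)c1cc2c(N/N=C/c3ccc(CN)cc3)ncnc2s1`, with aminomethyl in place of carboxy on an aromatic carbon, para to a large group: aminomethyl in place of carboxy on an aromatic carbon. Within the data shown here, the only measured step that bears on this change is a 78-fold higher number from compound 1 to compound 2 (1.89 log units; beyond the scatter), which is large and beyond the scatter. Its reverse direction suggests a large drop in this assay, though aminomethyl is not the (dimethylamino)methyl group itself, so a partial return is expected. The expected change is a 25-fold lower number from compound 2 to compound 3 (1.40 log units; beyond the scatter). The estimate for compound 3 is 0.4 ug/mL, within an expected range of 0.1 ug/mL to 2 ug/mL.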

Compound 3, half-maximal inhibitory concentration: 0.334 ug/mL
For compound 3 the middle estimate is 1.2-fold (0.08 log units) above the measured one, within the range that was stated.
By their numbers in this assay, from the lowest: compound 1; then compound 3; then compound 2.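

Aminomethyl in place of carboxy gives a 30-fold lower number from compound 2 to compound 3 (1.48 log units; beyond the scatter) in this assay, so the low numbers at this position do not depend on the (dimethylamino)methyl group alone. Amino in place of dimethylamino on the saturated chain carbon gives a 2.6-fold higher number from compound 1 to compound 3 (0.42 log units; beyond the scatter), a modest step that remains beyond the scatter. Nothing available explains either step.

Going by these compounds, whether a longer chain carrying the amine, a hydroxymethyl or a primary amide at this position would keep the number low stays open. On these data alone, how an ethylamino or a piperidinylmethyl group would compare with dimethylamino is also open.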